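A few compounds are considered here, and "the series" means these few. Any claim that something is new, unique, unknown or untested is made for them only; others in the source may bear on it.

In a functional assay on DU-145 cells (Homo sapiens) for antiproliferative activity, read by propidium iodide staining, with a stated time of 96 h (on this read-out lower numbers stand for stronger inhibition and higher numbers for weaker inhibition), compound 1 `CC(O)(CSc1ccc(S(F)(F)(F)(F)F)cc1)C(=O)Nc1cccc(S(F)(F)(F)(F)F)c1` gives 24800 nM. Compound 2 `CC(O)(CSc1ccc(F)cc1)C(=O)Nc1cccc(S(F)(F)(F)(F)F)c1` differs from compound 1 in a single place, (one fluorine atom in place of a group of 6 heavy atoms (5 fluorine, 1 sulfur; no ring), on an aromatic carbon), and in this assay compound 2 gives 38500 nM. The resulting step, a 1.6-fold higher number from compound 1 to compound 2 (0.19 log units; within the scatter), is therefore a small one. Compound 3 `CC(O)(CS(=O)(=O)c1ccc(S(F)(F)(F)(F)F)cc1)C(=O)Nc1ccc(S(F)(F)(F)(F)F)cc1` is built on a core unlike that of compound 1, and the difference between the two cores is not broken down here. In this assay compound 3 gives 28900 nM. Compound 4 `CC(O)(CS(=O)(=O)c1ccc(F)cc1)C(=O)Nc1ccc(S(F)(F)(F)(F)F)cc1` has not yet been tested. It differs from compound 3 by one fluorine atom in place of a group of 6 heavy atoms (5 fluorine, 1 sulfur; no ring), on an aromatic carbon, the same change that turned compound 1 into compound 2, made at the same kind of place on the ring. Because the earlier step of a 1.6-fold higher number from compound 1 to compound 2 (0.19 log units; within the scatter) stayed within the scatter, the step from compound 3 to compound 4 is expected to be of similar size, a 1.5-fold higher number from compound 3 to compound 4 (0.16 log units; within the scatter). On that basis compound 4 is estimated to give 42000 nM in this assay, with a likely range from 20000 nM to 90000 nM. Whether this expectation holds awaits the measurement.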

Compound 4, half-maximal inhibitory concentration: 27700 nM
Compound 4: middle estimate off by 1.5-fold (0.18 log units), on the high side; the measured number falls inside the stated range.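

In this assay, putting one fluorine atom in place of the group of 6 heavy atoms (5 fluorine, 1 sulfur) on an aromatic carbon gives a 1.0-fold lower number from compound 3 to compound 4 (0.02 log units; within the scatter). Set beside the earlier case, the change reads the same on both cores, as far as this read-out can tell: the same change on two cores in this assay, a 1.6-fold higher number (0.19 log units; within the scatter) from compound 1 to compound 2 and a 1.0-fold lower number (0.02 log units; within the scatter) from compound 3 to compound 4, 1.6-fold (0.21 log units) apart, within the scatter of two such steps. This shows that on these two cores the swap gives no step larger than the usual scatter of repeated measurements, but it does not show that the two groups are interchangeable in general, that the same would hold on a third core, or that a small dependence on the core is absent, since steps this small cannot reveal one.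

The compounds shown leave open what other groups on that aromatic carbon would do, such as an amine, a carboxylic acid or a longer chain. They also leave open whether this swap would read the same way in any other assay.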